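Adding a side chain to compound 2

The source may hold more compounds than are shown below. What is called first, only, known or untested is meant among the compounds shown, and "the series" means these compounds.

Measured in an ADME assay on PBMC cells (Homo sapiens) for cytotoxicity; on this read-out higher numbers stand for lower toxicity in this test and lower numbers for higher toxicity in this test:
compound 1 `O=Cc1ccc(-c2cc(-c3cccc(C=O)c3)c(O)c(O)c(=O)c2O)cc1` gives 6000 nM
compound 2 `CC(C)c1c(Cc2ccccc2)n(COCc2ccccc2)c(=O)[nH]c1=O` gives > 10000 nM, a limit of the assay

Compound 2 stands at > 10000 nM, and this is a limit of the assay, not a number. Its true value is therefore unknown, and any comparison starting from it is loose.

Compound 3 `CC(C)c1c(Cc2ccccc2)n(COCc2ccc(C(=O)/C=C(\O)C(=O)O)cc2)c(=O)[nH]c1=O` keeps everything in compound 2 except for one place. There, (2-carboxy-2-hydroxyethenyl)carbonyl stands in place of hydrogen on an aromatic carbon, para to a large group: (2-carboxy-2-hydroxyethenyl)carbonyl in place of hydrogen on an aromatic carbon.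

Among the measured compounds shown here, no measured pair of compounds shows what a change of this kind does in this assay, so there is no direct guide to its size or direction. The expected step is a step that the limit leaves unreadable from compound 2 to compound 3, with no change beyond the usual scatter anticipated in either direction. For the measured compounds named here, compound 1 at 6000 nM is the only exact number available, so the range is kept wide and reaches down into that region.

For compound 3 the estimated value is 12000 nM, with an expected range from 4000 nM to 40000 nM.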

Compound 3, half-maximal cytotoxic concentration: > 10000 nM
Compound 3: a limit, no number; the forecaster's own chance of this, stated with the estimate: 60%; the middle value lies beyond the limit too.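

In this assay compound 3 gives > 10000 nM, which is a limit of the assay and not a number. Compound 2 also stands at a limit, so no step can be read from one compound to the other: the limit of > 10000 nM in this assay, at which 2 of the 3 values shown sit.

The compounds shown leave open how far the true values of compound 2 and compound 3 lie beyond that limit, and so whether adding (2-carboxy-2-hydroxyethenyl)carbonyl changes the read-out at all.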